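The compounds below may be only part of what the source reports. "The series", "measured", "known", "first", "only" and "open" are said of these compounds alone.

Compound 3 `Cc1cc(-c2ccc(C#N)cc2)ccc1Oc1ccnc(Nc2ccc(C#N)cc2)n1` is one of three compounds tested in a functional assay on MT4 cells (Homo sapiens) for cytotoxicity, read by MTT assay, with a stated time of 5 days (on this read-out higher numbers stand for lower toxicity in this test and lower numbers for higher toxicity in this test), and for all three only a limit is available. In this assay compound 3 gives > 310000 nM, a limit rather than a number. In this assay compound 1 `Cc1cc(-c2ccc(C#N)c(F)c2)ccc1Oc1ccnc(Nc2ccc(C#N)cc2)n1` gives > 296000 nM, also a limit. In this assay compound 2 `N#Cc1ccc(Nc2nccc(Oc3ccc(-c4ccc(C#N)cc4)cc3Cl)n2)cc1` gives > 295000 nM, again a limit. The step from compound 3 to compound 4 `Cc1cc(-c2ccc(C#N)cc2F)ccc1Oc1ccnc(Nc2ccc(C#N)cc2)n1` is fluoro in place of hydrogen on an aromatic carbon. The two measured steps that bear on it are a step that the two limits leave unreadable from compound 1 to compound 3 and a step that the two limits leave unreadable from compound 2 to compound 3, both unreadable because every value sits at a limit (the limit of > 295000 nM in this assay, at which 1 of the 3 values shown sits, (the limit of > 296000 nM in this assay, at which 1 of the 3 values shown sits), (the limit of > 310000 nM in this assay, at which 1 of the 3 values shown sits)). No shift beyond the scatter is therefore expected in this assay, and compound 4 is expected to give 300000 nM (range 150000 nM to 600000 nM), a step estimated as an at least 1.0-fold lower number from compound 3 to compound 4 (0.01 log units; that floor lies within the scatter).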

Compound 4, half-maximal cytotoxic concentration: > 296000 nM
Compound 4 ended at the assay's limit; the forecaster's own chance of this, stated with the estimate: 90%; the middle value lies beyond the limit too.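

Among the compounds shown here, no step to compound 4 from compound 3 or from compound 1 can be read in this assay; all three values are limits. The compounds shown leave open at what concentration any of them turns toxic, and whether fluoro alters that.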